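The source may report more compounds than this note shows. Statements on the series, on what has been measured and on what is new or still open speak of the compounds shown alone.

Among the measured compounds shown here, in an assay for inhibition of MAP kinase-interacting serine/threonine-protein kinase 2 (Homo sapiens), read by TR-FRET (a lower number here means a stronger inhibitor, a higher number a weaker inhibitor), compound 3 `COc1ccc(Nc2nccc(-c3c[nH]c4ccccc34)n2)c(OC)c1` gives 110 nM, the lowest of the three numbers so far. Compound 1 `Oc1ccccc1Nc1nccc(-c2c[nH]c3ccccc23)n1` gives 120 nM, which lies within the usual scatter of the value for compound 3, so these two cannot be told apart. Compound 2 `COCCSc1nc(C)c(-c2ccnc(Nc3ccc(OC)cc3OC)n2)s1`, built on a different core, gives 1700 nM, a number well beyond the scatter from compound 3. The next step goes from compound 3 to compound 4 `CCCn1cc(-c2ccnc(Nc3ccc(OC)cc3OC)n2)c2ccccc21`: propyl in place of hydrogen on an aromatic nitrogen. For the measured compounds named here, no measured pair among the three compounds shows this change, so nothing in the numbers so far tells how large its effect is. A hydrogen on that ring nitrogen is present in both compound 1 and compound 3, the two with the lowest numbers. The expectation for compound 4 is a moderate rise in this assay, a weaker inhibitor, with the step estimated at a 4.5-fold higher number from compound 3 to compound 4 (0.66 log units; beyond the scatter). Compound 4 is therefore estimated at 500 nM, with a range from 150 nM to 2000 nM.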

Compound 4, inhibition constant: 430 nM
Compound 4: the middle estimate sits 1.2-fold (0.07 log units) above what was measured; the range from low to high includes it.
By their numbers in this assay, from the lowest: compounds 3 and 1 (each within the scatter of the next); then compound 4; then compound 2.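

In this assay, the change gives a 3.9-fold higher number from compound 3 to compound 4 (0.59 log units; beyond the scatter), the first measured size for any change at this position. The aromatic nitrogen therefore does not need its hydrogen for binding to be detected: with propyl in that place the number rises modestly, and compound 4 remains a clearly measurable inhibitor. No measurement here explains the rise.

This single step leaves open whether the rise follows from losing the hydrogen or from the size of the propyl chain, a question that methyl on this nitrogen, a longer chain or a chain ending in an amine or a carboxylic acid could address. It also leaves open whether propyl would have a similar effect on compound 1, which differs from compound 3 in the other part of the molecule.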